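The compounds below may be only part of what the source reports. "The series", "measured", "known", "first", "only" and "open" are said of these compounds alone.

Compound 1 `Cc1cc(C)cc(Oc2ccc3nc(COc4cccc(C(=O)O)c4)n(C)c3n2)c1` gives 17.4 10^-6 cm/s in an ADME assay for permeability, using PAMPA, with a stated time of 4 h; on this read-out higher numbers stand for higher permeability and lower numbers for lower permeability. Compound 2 `Cn1c(COc2cccc(C(=O)O)c2)nc2ccc(Oc3ccc4c(c3)CCC4)nc21` gives 31.5 10^-6 cm/s. Compound 3 `Cn1c(COc2cccc(C(=O)O)c2)nc2ccc(Oc3ccc(Cl)cn3)cc21` gives 16.2 10^-6 cm/s.

On these numbers compound 3 has the smallest value of the three, but its gaps to compound 1 and to compound 2 are both within the scatter, so the three stand together. Compound 4 `Cc1ccnc(Oc2ccc3nc(COc4cccc(C(=O)O)c4)n(C)c3c2)c1` differs from compound 3 by 4-methylpyridin-2-yl in place of 5-chloropyridin-2-yl on an oxygen on an aromatic ring. Within the data shown here, only one measured step touches the same place, the swap of aryl groups on that oxygen, which gave a 1.8-fold higher number from compound 1 to compound 2 (0.26 log units; within the scatter). Among the measured compounds shown here, no measured pair swaps one pyridyl group for another, so the expectation rests on that single step. Compound 4 is therefore expected to show a 1.0-fold higher number from compound 3 to compound 4 (0.02 log units; within the scatter) in this assay, nothing beyond the scatter. The estimated value of compound 4 is 17 10^-6 cm/s, between 9 10^-6 cm/s and 32 10^-6 cm/s.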

Compound 4, apparent permeability: 3.5 10^-6 cm/s
Compound 4: middle estimate off by 4.9-fold (0.69 log units), on the high side; the whole stated range lies above it.
By their numbers in this assay, from the lowest: compound 4; then compounds 3, 1 and 2 (each within the scatter of the next).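

In this assay, the change from (5-chloropyridin-2-yl)oxy to (4-methylpyridin-2-yl)oxy gives a 4.6-fold lower number from compound 3 to compound 4 (0.67 log units; beyond the scatter). This shows that a swap on this oxygen can move the read-out beyond the scatter, which the earlier swap, a 1.8-fold higher number from compound 1 to compound 2 (0.26 log units; within the scatter), did not. No measurement shown here explains this step.

Since the chlorine leaves as the methyl enters, the compounds shown do not separate the effect of losing one group from that of gaining the other. Going by these compounds, how a plain pyridin-2-yl group or an amine on that ring would read remains open.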